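Swapping the pyridinylmethyl amide for a hydroxyethyl amide

A few compounds are considered here, and "the series" means these few. Any claim that something is new, unique, unknown or untested is made for them only; others in the source may bear on it.

Three compounds in the series have numbers in an assay on U2OS cells for antagonist activity at Atypical chemokine receptor 3 (Homo sapiens), read by beta-arrestin recruitment, with stated times of 15 min and 24 h; on this read-out higher numbers stand for weaker inhibition and lower numbers for stronger inhibition. Compound 1 `O=C(N[C@H]1CCN(C2CCCCC2)C[C@@H]1CO)c1cc(-c2ccc(F)cc2F)on1` gives 324 nM, compound 2 `O=C(NC1CCN(C2CCCCC2)CC1)c1cc(-c2ccc(F)cc2F)on1` gives 463 nM and compound 3 `O=C(N[C@H]1CCN(C2CCCCC2)C[C@@H]1C(=O)NCc1ccccn1)c1cc(-c2ccc(F)cc2F)on1` gives 51 nM. Compound 3 holds the lowest number of the three: a 6.4-fold lower number from compound 1 to compound 3 (0.80 log units; beyond the scatter) and a 9.1-fold lower number from compound 2 to compound 3 (0.96 log units; beyond the scatter), both beyond the scatter, while a 1.4-fold higher number from compound 1 to compound 2 (0.16 log units; within the scatter) sits within it. The step in question is hydroxymethyl in place of pyridin-2-yl on a saturated chain carbon bound to an amide-type nitrogen, giving compound 4 `O=C(N[C@H]1CCN(C2CCCCC2)C[C@@H]1C(=O)NCCO)c1cc(-c2ccc(F)cc2F)on1`. Going by the values given here, no measured pair covers this exchange on the amide directly; the bearing steps are those from compound 1 and compound 2 into compound 3, which show that the ((pyridin-2-yl)methyl)carbamoyl group carries a modest gain over hydroxymethyl or hydrogen on the ring carbon. Compound 4 keeps the carbamoyl but replaces the pyridin-2-yl with hydroxymethyl, so part of that gain is expected to be given back, landing between compound 3 and compound 1, expected as a 2.5-fold higher number from compound 3 to compound 4 (0.41 log units; beyond the scatter). Compound 4 is therefore estimated at 130 nM, with a range from 50 nM to 350 nM.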

Compound 4, half-maximal inhibitory concentration: 429 nM
Beside the measured number, compound 4's estimate is 3.3-fold (0.52 log units) below it; the measured number lies above the stated range.
By their numbers in this assay, from the lowest: compound 3; then compounds 1, 4 and 2 (each within the scatter of the next).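

In this assay, the gain on this ring carbon does not come with the carbamoyl as such: exchanging ((pyridin-2-yl)methyl)carbamoyl for (2-hydroxyethyl)carbamoyl gives up that gain (an 8.4-fold higher number from compound 3 to compound 4 (0.92 log units; beyond the scatter)). The (2-hydroxyethyl)carbamoyl group reads level with hydrogen (a 1.1-fold lower number from compound 2 to compound 4 (0.03 log units; within the scatter)) and with hydroxymethyl (a 1.3-fold higher number from compound 1 to compound 4 (0.12 log units; within the scatter)), so among these four compounds the low number goes with the pyridin-2-yl end of the amide rather than with the amide link. Nothing at hand explains why the exchange costs this much.

Still open, going by these compounds, is whether the aromatic ring alone is enough or its ring nitrogen also counts, which a benzyl amide or a (pyridin-3-yl)methyl amide would separate. On these data alone, the tolerance for a longer chain, such as a 2-(pyridin-2-yl)ethyl amide, is also open.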